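The source may hold more compounds than are shown below. What is called first, only, known or untested is meant among the compounds shown, and "the series" means these compounds.

Measured so far in a functional assay on HCT-116 cells (Homo sapiens) for antiproliferative activity, read by CCK-8 assay, with a stated time of 72 h; on this read-out higher numbers stand for weaker inhibition and lower numbers for stronger inhibition:
- compound 1 `CC1=NN(c2ccc(Br)cc2)C(=O)C12C=CC(=O)C=C2c1ccccc1`: > 100000 nM
- compound 2 `CC1=NN(c2cccc(Cl)c2)C(=O)C12C=CC(=O)C=C2c1ccccc1`: 7000 nM

Compound 1 sits at the limit of this assay and has no numerical value; the figure given for it is only that limit (the limit of > 100000 nM in this assay, at which 1 of the 2 values shown sits). Compound 2 returns a number within the measurable range.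

Within the data shown here, the single measured step, an at least 14-fold lower number from compound 1 to compound 2 (1.15 log units; beyond the scatter), concerns the aryl group on the amide-type nitrogen in the ring. It says nothing about the phenyl attached to the core.

Compound 3 `CC1=NN(c2ccc(Br)cc2)C(=O)C12C=CC(=O)C=C2c1ccc(C)cc1` differs from compound 1 by methyl in place of hydrogen on an aromatic carbon, which reads as phenyl to 4-methylphenyl. Among the measured compounds shown here, no measured step in this assay bears on this change, and compound 1, the starting point, is itself known only as a limit. Nothing in the data therefore argues for a step in either direction beyond the scatter.

Compound 3 is accordingly expected to sit at about 100000 nM, plausibly between 20000 nM and 300000 nM. This estimate means a step of a number no higher from compound 1 to compound 3 (the limit leaves the size open) and most likely another reading at the limit rather than a number.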

Compound 3, half-maximal inhibitory concentration: 10600 nM
The estimate for compound 3 lay 9.4-fold (0.97 log units) above the measured number, and the stated range ends above it.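

The phenyl attached to the core is a position that responds in this assay: methyl in place of hydrogen on an aromatic carbon, which reads as phenyl to 4-methylphenyl, gives an at least 9.4-fold lower number from compound 1 to compound 3 (0.97 log units; beyond the scatter). With the 4-bromophenyl kept on the amide-type nitrogen, this one methyl moves the read-out from the limit to a number in the measurable range, so that aryl group alone does not hold the series at the limit. The true size of the step remains open, since compound 1 is known only as a limit: the limit of > 100000 nM in this assay, at which 1 of the 3 values shown sits.

The compounds shown leave open whether the step belongs to methyl in particular or would also follow from ethyl, methoxy, fluorine or an amine in the same place on this phenyl. They also leave open whether the 4-methylphenyl would lower the number to a similar extent with the 3-chlorophenyl of compound 2 on the amide-type nitrogen, or whether the two changes would fail to add up.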